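Benzamide in place of the dichlorophenyl urea on the core

This account rests on a few compounds, and the source may have more. Where it says the series, first, only, none or still open, it means among the compounds named here.

Compound 1 `COc1cc(-c2nn(-c3cccc(NC(=O)Nc4ccc(Cl)c(Cl)c4)c3)cc2-c2ccncc2)ccc1Cl` is the reference point. In a functional assay on ACHN cells (Homo sapiens) for inhibition, read by sulforhodamine B assay, with a stated time of 48 h (a higher number here means that more compound is tolerated, a lower number that less compound is tolerated), compound 1 gives > 50000 nM, which is a limit of the assay and not a number. Compound 2 `O=C(Nc1cccc(-n2cc(-c3ccncc3)c(-c3ccc(Cl)c(O)c3)n2)c1)Nc1ccc(Cl)c(Cl)c1` carries hydrogen in place of methyl on an oxygen on an aromatic ring. In this assay compound 2 gives > 32500 nM, again a limit rather than a number. The step that the two limits leave unreadable from compound 1 to compound 2 is therefore unreadable in size; compound 1 sits at the limit of > 50000 nM in this assay, at which 1 of the 2 values shown sits, and compound 2 at the limit of > 32500 nM in this assay, at which 1 of the 2 values shown sits, so the pair shows only that neither is tolerated less than those limits.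

Compound 3 `COc1cc(-c2nn(-c3cccc(NC(=O)c4ccccc4)c3)cc2-c2ccncc2)ccc1Cl` is not yet measured. It differs from compound 1 by phenyl in place of (3,4-dichlorophenyl)amino on a carbonyl carbon. For the measured compounds named here, no measured step touches this carbonyl carbon, so the one step on record gives no size to carry over. Compound 3 is expected to sit at 40000 nM in this assay, within 10000 nM to 100000 nM, a change of an at least 1.2-fold lower number from compound 1 to compound 3 (0.09 log units; that floor lies within the scatter) that is estimated to stay within the scatter and most likely to appear only as a limit.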

Compound 3, concentration lethal to 50% of the cells: > 100000 nM
Compound 3: no number, only a limit; the forecaster's own chance of this, stated with the estimate: 70%; at least 2.5-fold (0.39 log units) between middle value and limit.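

In this assay compound 3 gives > 100000 nM, a limit of the assay and not a number. For the compounds shown here, compound 1 also stands only at a limit, and no step from compound 1 to compound 3 can be read. The compounds shown leave open whether phenyl or (3,4-dichlorophenyl)amino on the carbonyl carbon makes any difference in this assay.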